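Swapping a Branched Group for a Straight Chain

The source may report more compounds than this note shows. Statements on the series, on what has been measured and on what is new or still open speak of the compounds shown alone.

Three closely related ureas have been measured so far. Compound 1 `CCc1ccccc1NC(=O)N[C@H](C)c1ccccc1` is tested in an ADME assay on the whole organism with Oryza sativa as the target, tested at 0.1 uM (on this read-out higher numbers stand for a weaker effect at the one concentration tested and lower numbers for a stronger effect), where compound 1 gives 101%. Compound 2 `C[C@@H](NC(=O)Nc1ccc(C(C)(C)C)cc1)c1ccccc1` and compound 3 `C[C@H](NC(=O)Nc1ccc(C(C)(C)C)cc1)c1ccccc1` carry a tert-butyl group on the aromatic ring instead, and in this assay compound 2 gives 100% while compound 3 gives 100%. Going by the values given here, the only measured step is no change at the digits printed from compound 2 to compound 3 (within the scatter), which matches (the fact that compounds 2 and 3 differ only in the configuration as drawn). Compound 3 therefore sits level with compound 2, and all three numbers lie within the scatter of one another: none of the three compounds shows an effect at the concentration tested.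

The next compound, compound 4 `CCCCCCCc1ccc(NC(=O)N[C@@H](C)c2ccccc2)cc1`, is to be measured in this assay. Compared with compound 3 the change is heptyl in place of tert-butyl on an aromatic carbon. Among the compounds with values here, no measured step involves such a change; the single step seen, no change at the digits printed from compound 2 to compound 3 (within the scatter), only swapped the drawn configuration and left the number unchanged within the scatter. With every measured compound close to the no-effect level, the expected step of a number 2 percentage points lower from compound 3 to compound 4 (within the scatter) is none beyond the scatter, though the exchange of the chain adds some uncertainty. Compound 4 is thus estimated to give 98%, with a range from 84% to 108%.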

Compound 4, a percentage reported as activity, at one concentration (the size of the read-out at that concentration, not a potency): 100%
For compound 4 the middle estimate is 2 percentage points below the measured one; the measured number falls inside the stated range.
By their numbers in this assay, from the lowest: compounds 2, 3, 4 and 1 (each within the scatter of the next).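

In this assay, heptyl in place of tert-butyl on an aromatic carbon gives no change at the digits printed from compound 3 to compound 4 (within the scatter). Going by these compounds alone, earlier, the only measured step changed the configuration as drawn, whereas this step changes the group itself: a straight chain of 7 carbon atoms replaces a branched group of 4 carbon atoms at the same place, para to a large group, and the read-out stays within the scatter, so this exchange leaves the compound without a visible effect at the one concentration tested. None of the facts at hand bears on why the number stays where it is.

From the compounds shown here alone, it remains open whether a group of a different kind at this place on the ring, such as an amine or a carboxylic acid, would move the number beyond the scatter, since both groups compared here are made of carbon only and carry no ring, hydrogen-bond donors or acceptors, or net charge. Going by these compounds, it also remains open how these ureas would behave at any other concentration, since a reading at one concentration is not a potency.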